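Hexyl for trifluoromethoxy on the aniline ring of compound 1

The source may report more compounds than this note shows. Statements on the series, on what has been measured and on what is new or still open speak of the compounds shown alone.

Compound 1 `Cc1nc2c(s1)C(=O)C=C(Nc1ccc(OC(F)(F)F)cc1)C2=O` carries a trifluoromethoxy group on its aniline ring. In a functional assay on HepG2 cells (Homo sapiens) for cytotoxicity, read by MTT assay (a lower number here means a stronger inhibitor, a higher number a weaker inhibitor), compound 1 gives only a limit, > 100 ug/mL, and no number. Compound 2 `Cc1nc2c(s1)C(=O)C=C(Nc1cccc(Cl)c1)C2=O` gives 5.7 ug/mL in this assay, and compound 3 `O=C1C=C(Nc2ccc(Cl)cc2)C(=O)c2scnc21` gives 16.4 ug/mL. Compound 1 thus sits at the weak end of what has been measured, at the limit of the method (the limit of > 100 ug/mL in this assay, at which 1 of the 3 values shown sits), while compounds 2 and 3 give numbers inside the measurable range.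

The change to compound 4 `CCCCCCc1ccc(NC2=CC(=O)c3sc(C)nc3C2=O)cc1` is hexyl in place of trifluoromethoxy on an aromatic carbon, on a six-membered aromatic ring of carbon only, para to a large group. Among the measured compounds shown here, no measured pair of compounds differs in only this place, so the size of the step cannot be read from a neighbour.

Since compound 1 rests at a limit, any number for compound 4 would already be a step beyond the scatter, and the expectation here is for a gain toward the range where compounds 2 and 3 sit, though a second limit remains quite possible. For compound 4 the estimate in this assay is 30 ug/mL, with a range from 8 ug/mL to 100 ug/mL. The step from compound 1 to compound 4 that this estimate implies is an at least 3.3-fold lower number from compound 1 to compound 4 (0.52 log units; beyond the scatter).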

Compound 4, half-maximal inhibitory concentration: 22 ug/mL
The estimate for compound 4 lay 1.4-fold (0.13 log units) above the measured number, within the range that was stated.
By their numbers in this assay, from the lowest: compound 2; then compounds 3 and 4 (each within the scatter of the next). At a limit, above all of these: compound 1.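

Hexyl in place of trifluoromethoxy on this aromatic carbon gives the first step in the series that can be read at a single place: in this assay it is an at least 4.5-fold lower number from compound 1 to compound 4 (0.65 log units; beyond the scatter). Compound 1 gives > 100 ug/mL, which is a limit and not a number, so the step fixes only a bound and not a full size: the limit of > 100 ug/mL in this assay, at which 1 of the 4 values shown sits. The group at this position therefore matters to the read-out, since with hexyl in place, compound 4 gives 22 ug/mL, a number inside the measurable range.

A single pair cannot separate the loss of trifluoromethoxy from the arrival of hexyl, and a butyl chain, a longer chain such as octyl, or a carboxylic acid or an amine at this position would show whether the number follows the chain or the group that left. Going by these compounds, compound 2 and compound 3 each differ from compound 4 in more than one place, so how hexyl behaves on those compounds remains open.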